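The source may hold more compounds than are shown below. What is called first, only, known or untested is meant among the compounds shown, and "the series" means these compounds.

Measured so far in a functional assay on 786-0 cells (Homo sapiens) for cytotoxicity, read by sulforhodamine B assay, with a stated time of 48 h, tested at 10 uM; on this read-out lower numbers stand for a stronger effect and higher numbers for a weaker effect at the one concentration tested:
compound 1, `COc1cc(-c2cc(/C=C/C(=O)c3ccc(N)cc3)[nH]n2)cc(OC)c1OC`: compound 1 gives -19%
compound 2, `COc1ccc(C(=O)/C=C/c2cc(-c3cc(OC)c(OC)c(OC)c3)n[nH]2)cc1OC`: compound 2 gives -88%

Among the measured compounds shown here, on these two numbers compound 2 stands lowest; its only neighbour is compound 1, and the one measured step, a number 69 percentage points lower from compound 1 to compound 2 (beyond the scatter), is large and beyond the scatter. For the measured compounds named here, it runs through a change of the aryl ring on the carbonyl carbon and is the only step on record.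

The next compound, compound 3, is `COc1ccc(C(=O)/C=C/c2cc(-c3cc(OC)c(OC)c(OC)c3)n[nH]2)cc1`. It differs from compound 2 by hydrogen in place of methoxy on an aromatic carbon. Going by the values given here, no measured step removes a methoxy group from the shared core, so the step from compound 1 to compound 2 bears on it only loosely: it shows that the aryl ring on the carbonyl carbon matters strongly, without saying how much of that rests on the methoxy that leaves here. A partial loss of effect, that is a number higher than compound 2, is expected for compound 3, with the step estimated as a number 33 percentage points higher from compound 2 to compound 3 (beyond the scatter). For compound 3 the estimate in this assay is -55%, with a range from -90% to -10%.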

Compound 3, a percentage reported as activity, at one concentration (the size of the read-out at that concentration, not a potency): -59%
Compound 3: the middle estimate sits 4 percentage points above what was measured, and the stated range covers the measured number.
By their numbers in this assay, from the lowest: compound 2; then compound 3; then compound 1.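

In this assay, the loss of one methoxy from the 3,4-dimethoxyphenyl ring gives a number 29 percentage points higher from compound 2 to compound 3 (beyond the scatter), so this single group accounts for a real part of the effect, while the 4-methoxyphenyl ring of compound 3 still retains much of it. The change at the other substituted carbon, a number 40 percentage points lower from compound 1 to compound 3 (beyond the scatter), shows that methoxy in place of amino also matters, and thus the earlier large difference, a number 69 percentage points lower from compound 1 to compound 2 (beyond the scatter), comes apart into two separately measurable changes, each beyond the scatter. The data on hand offer no explanation for either change.

The compounds shown leave open how a hydroxy group, a fluorine atom or a longer ether such as ethoxy would read in place of either methoxy on this ring, and whether a plain phenyl ring on the carbonyl carbon would keep any of the effect. On these data alone, the methoxy groups of the shared core stay the same in all three compounds, so their share in the effect also remains open.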